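Chain-extended amino ester of the chromone core

The source may report more compounds than this note shows. Statements on the series, on what has been measured and on what is new or still open speak of the compounds shown alone.

Measured so far in a functional assay on HeLa cells (Homo sapiens) for cytotoxicity, read by neutral red uptake, with a stated time of 3 days; on this read-out higher numbers stand for weaker inhibition and lower numbers for stronger inhibition: compound 1 `Nc1ccc(-c2cc(=O)c3c(N)c(F)c(O)c(F)c3o2)cc1F` gives > 100000 nM there. Compound 2 `CN(C)CCC(=O)OCc1c(F)c(N)c2c(=O)cc(-c3ccc(N)c(F)c3)oc2c1F` gives 11000 nM in the same assay.

For compound 1 the value > 100000 nM is a limit of this assay, not a number; it is the single case of the limit of > 100000 nM in this assay, at which 1 of the 2 values shown sits, among the two values. Among the compounds with values here, compound 2 holds the only actual number in this assay, 11000 nM, and the step of an at least 9.0-fold lower number from compound 1 to compound 2 (0.95 log units; beyond the scatter) is the only measured step in the set.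

Compound 3 `CN(C)CCCC(=O)OCc1c(F)c(N)c2c(=O)cc(-c3ccc(N)c(F)c3)oc2c1F` carries the change ((dimethylamino)methyl in place of dimethylamino on a saturated chain carbon, two bonds along the chain from a carbonyl carbon). No measured step follows this kind of change; the one step shown, from compound 1 to compound 2, exchanges the hydroxy for the whole amino ester and so gives no guide to lengthening the chain inside that ester by one carbon. With nothing to point either way, the expectation for this assay is a step within the scatter, no change at the digits printed from compound 2 to compound 3 (within the scatter), in no preferred direction.

Compound 3 is therefore estimated at 11000 nM, with a range from 4000 nM to 35000 nM.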

Compound 3, half-maximal inhibitory concentration: 4500 nM
The estimate for compound 3 lay 2.4-fold (0.39 log units) above the measured number, within the range that was stated.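

In this assay, (dimethylamino)methyl in place of dimethylamino on a saturated chain carbon, two bonds along the chain from a carbonyl carbon, gives a 2.4-fold lower number from compound 2 to compound 3 (0.39 log units; beyond the scatter). The length of the chain inside the amino ester therefore has a readout of its own, which the earlier exchange of the hydroxy for the whole ester could not separate from the presence of the ester itself. Set against the hydroxy compound, the longer ester gives an at least 22-fold lower number from compound 1 to compound 3 (1.34 log units; beyond the scatter), and this step is only a bound, since compound 1 stands at a limit of this assay and not at a number: the limit of > 100000 nM in this assay, at which 1 of the 3 values shown sits.

As far as these compounds go, the two ester chains fix a direction for this one pair only, and whether it continues with a longer chain, such as one ending in 4-(dimethylamino)butyl, stays open. Also open, from the compounds shown here alone, is how much depends on the dimethylamino end itself, as against a piperidine ring or a carboxylic acid at the chain end, and on the ester link, as against an amide.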